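Azetidine amide series: carbocycle versus pyrrolidine on the carbonyl

The source may hold more compounds than are shown below. What is called first, only, known or untested is meant among the compounds shown, and "the series" means these compounds.

Compound 1 `CC1CCCC(C(=O)N2CC(c3nc(-c4cccc(Cl)c4)no3)C2)C1` carries a 3-methylcyclohexyl group on the carbonyl carbon, and in an assay on HEK293 cells for positive allosteric modulation of metabotropic glutamate receptor 5 (Homo sapiens), read by FLIPR (on this read-out higher numbers stand for an effect only at larger amounts of compound and lower numbers for an effect already at smaller amounts), compound 1 gives 410 nM. Compound 2 `CC1CCN(C(=O)N2CC(c3nc(-c4cccc(Cl)c4)no3)C2)C1` has 3-methylpyrrolidin-1-yl in that place. In this assay compound 2 gives only a limit, > 10000 nM, not a number. Compound 2 therefore sits at the limit of > 10000 nM in this assay, at which 1 of the 2 values shown sits, and the step of an at least 24-fold higher number from compound 1 to compound 2 (1.38 log units; beyond the scatter) is the one large movement seen so far in the pair.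

Compound 3 `O=C(C1CCC(F)(F)CC1)N1CC(c2nc(-c3cccc(Cl)c3)no2)C1` is not yet measured. Relative to compound 2 it carries 4,4-difluorocyclohexyl in place of 3-methylpyrrolidin-1-yl on a carbonyl carbon. Among the compounds with values here, the one measured step that bears on this change is an at least 24-fold higher number from compound 1 to compound 2 (1.38 log units; beyond the scatter), which ran the corresponding swap in the opposite direction, from a substituted cyclohexyl to a substituted pyrrolidinyl. Reversing that swap is expected to recover a large part of the loss in this assay, so a large step downward in the read-out, an at least 20-fold lower number from compound 2 to compound 3 (1.30 log units; beyond the scatter), is expected for compound 3. Compound 3 is estimated at 500 nM in this assay, with a range from 150 nM to 3000 nM.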

Compound 3, half-maximal effective concentration: 180 nM
Compound 3: middle estimate off by 2.8-fold (0.44 log units), on the high side; low and high end bracket the measured number.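

In this assay the place on the carbonyl carbon now shows an at least 55-fold lower number from compound 2 to compound 3 (1.74 log units; beyond the scatter), so the measurable response returns with a second carbocycle and is not tied to the 3-methylcyclohexyl group of compound 1. Between the two cyclohexyl groups the movement is only modest, a 2.3-fold lower number from compound 1 to compound 3 (0.36 log units; beyond the scatter), so among the three compounds the two carrying a six-membered carbon ring give numbers, while compound 2, with 3-methylpyrrolidin-1-yl, is the one that goes against them. The true size of the step from compound 2 remains open on one side, as compound 2 gives only a limit: the limit of > 10000 nM in this assay, at which 1 of the 3 values shown sits.

The compounds shown do not separate ring size from a ring nitrogen attached to the carbonyl, since 3-methylpyrrolidin-1-yl differs from both cyclohexyl groups in both respects; a piperidin-1-yl or a 3-methylcyclopentyl group in this place would pull the two apart. An unsubstituted cyclohexyl group would also give a common reference for reading the methyl group and the two fluorine atoms separately.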